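Amide step from compound 2 to compound 3

A few compounds are considered here, and "the series" means these few. Any claim that something is new, unique, unknown or untested is made for them only; others in the source may bear on it.

- compound 1 `C[C@H](Nc1ncnc(N)c1C#N)c1nc2ccc(F)cc2c(C(N)=O)c1-c1ccccc1` - < 14 mL.min-1.g-1 (a limit)
- compound 2 `C[C@H](Nc1ncnc(N)c1C#N)c1nc2ccc(F)cc2c(C(=O)N(C)C)c1-c1ccccc1` - 426 mL.min-1.g-1
- compound 3 `CCNC(=O)c1c(-c2ccccc2)c([C@H](C)Nc2ncnc(N)c2C#N)nc2ccc(F)cc12` - not yet measured

Going by the values given here, in an ADME assay on microsomes from liver (Rattus norvegicus) for pharmacokinetics, using NADPH, with a stated time of 30 min, tested at 1 uM (on this read-out lower numbers stand for slow clearance and higher numbers for fast clearance), compound 2 gives 426 mL.min-1.g-1, the only true number so far. Compound 1 gives < 14 mL.min-1.g-1, which is a limit of the assay.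

The next change is ethylamino in place of dimethylamino on a carbonyl carbon. Among the compounds with values here, the one measured step at this carbon is an at least 30-fold higher number from compound 1 to compound 2 (1.48 log units; beyond the scatter), large and beyond the scatter. On that basis a lower number is expected in this assay, partway back along that step. The expected size is a 4.7-fold lower number from compound 2 to compound 3 (0.68 log units; beyond the scatter). Compound 3 is estimated at 90 mL.min-1.g-1, with a range from 25 mL.min-1.g-1 to 300 mL.min-1.g-1.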

Compound 3, intrinsic clearance in microsomes: < 14 mL.min-1.g-1
Compound 3: only a limit was reported; the forecaster's own chance of this, stated with the estimate: 10%; at least 6.4-fold (0.80 log units) between middle value and limit.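

In this assay, ethylamino in place of dimethylamino on the carbonyl carbon, with the heavy-atom count unchanged, gives an at least 30-fold lower number from compound 2 to compound 3 (1.48 log units; beyond the scatter). The high number of compound 2 therefore does not follow from the heavy-atom count of this group alone. Of the compounds shown, only compound 2 lacks the amide hydrogen, and only compound 2 gives a true number rather than a limit.

The step between compound 1 and compound 3 cannot be read, because both values are the same limit: the limit of < 14 mL.min-1.g-1 in this assay, at which 2 of the 3 values shown sit. As far as these compounds go, whether a longer chain, such as butyl, on the amide nitrogen also keeps the number at that limit remains open.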